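The compounds below may be only part of what the source reports. "The series", "measured", "known", "first", "only" and "open" are said of these compounds alone.

Working notes on the series. In a functional assay on CHO cells for agonist activity at Alpha-1A adrenergic receptor (Homo sapiens), read by FLIPR and calcium flux (on this read-out higher numbers stand for larger maximal responses and lower numbers for smaller maximal responses), compound 1 `Clc1ccccc1C1Cc2nccn2C1` gives 56%, the highest of the three numbers recorded. Compound 3 `Clc1ccc(C2Cc3nccn3C2)cc1` sits nearest, giving 45% in this assay, a gap beyond the scatter; compound 2 `c1ccc2c(c1)CC(c1ncc[nH]1)C2` lies furthest, with 26% in this assay. No pair among these three differs in a single place, so no single-point step is available from the measured compounds.

Compound 4 `NC(=O)c1ccccc1C1Cc2nccn2C1` has not yet been run in this assay. It differs from compound 1 as follows: carbamoyl in place of chloro on an aromatic carbon. With nothing in the series to anchor this change, the expected step is a moderate decrease, a number 16 percentage points lower from compound 1 to compound 4 (beyond the scatter), though a result within the scatter of compound 1 cannot be excluded. Compound 4 is therefore estimated to give 40%, ranging from 15% to 65%, in this assay.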

Compound 4, largest response reached (Emax), in percent of the reference or control that the assay uses: 87%
Compound 4: the middle estimate sits 47 percentage points below what was measured, outside the stated range (above it).
By their numbers in this assay, from the lowest: compound 2; then compound 3; then compound 1; then compound 4.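

Carbamoyl in place of chloro on this aromatic carbon, ortho to a group of 8 heavy atoms, gives a number 31 percentage points higher from compound 1 to compound 4 (beyond the scatter) in this assay. This position therefore accepts a larger group than chloro, and the maximal response can rise substantially with that change. The change adds a hydrogen-bond donor and a hydrogen-bond acceptor, but no measurement here links the rise to either feature or otherwise accounts for it.

A carboxylic acid, an aminomethyl group or a methyl amide on the same carbon would test how specific the rise is to carbamoyl. Going by these compounds, whether carbamoyl in place of the chloro of compound 3 brings a similar rise also remains open.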